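Swapping the Aryl Ring for an Ester Side Chain

This account rests on a few compounds, and the source may have more. Where it says the series, first, only, none or still open, it means among the compounds named here.

compound 1 `COc1cccc(-c2csc(N/N=C/c3ccc4cc(OC)ccc4c3)n2)c1` — 21.9%
compound 2 `COc1ccc(-c2csc(N/N=C/c3ccc4cc(OC)ccc4c3)n2)cc1` — 28.1%

In an assay on isolated protein for inhibition of Amine oxidase [flavin-containing] A (Homo sapiens), tested at 10 mM (on this read-out lower numbers stand for a stronger effect and higher numbers for a weaker effect at the one concentration tested), compound 2 gives 28.1%, the higher of the two numbers, while compound 1 gives 21.9%; the step of a number 6.2 percentage points higher from compound 1 to compound 2 (within the scatter) lies within the scatter. Compound 3 `CCOC(=O)Cc1csc(N/N=C/c2ccc3cc(OC)ccc3c2)n1` differs from compound 2 by (ethoxycarbonyl)methyl in place of 4-methoxyphenyl on an aromatic carbon. Among the measured compounds shown here, no measured step involves this exchange: the only step known, moving a methoxy around a phenyl ring, says nothing about replacing that ring with a chain. Therefore no step beyond the scatter is expected, though the uncertainty is wide. Compound 3 is estimated at 22%, between 5% and 40%, an expected step of a number 6.1 percentage points lower from compound 2 to compound 3 (within the scatter).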

Compound 3, a percentage reported as inhibition, at one concentration (the size of the read-out at that concentration, not a potency): 30.2%
Compound 3: middle estimate off by 8.2 percentage points, on the low side; measured number inside the range.
By their numbers in this assay, from the lowest: compounds 1, 2 and 3 (each within the scatter of the next).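

The exchange removes the six-membered aromatic ring altogether and puts (ethoxycarbonyl)methyl on the same aromatic carbon, yet this assay shows a number 2.1 percentage points higher from compound 2 to compound 3 (within the scatter) and a number 8.3 percentage points higher from compound 1 to compound 3 (within the scatter). Across these three compounds, then, a ringless ester chain at this position reads the same as either methoxyphenyl group, so the aryl ring is not required to hold this number. Nothing available explains this result.

From the compounds shown here alone, whether an amine, a carboxylic acid or a longer chain on this carbon would shift the number beyond the scatter stays open.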